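The compounds below may be only part of what the source reports. "The series", "measured", "known", "first", "only" and "open" are said of these compounds alone.

Compound 2 `CC(C)(C)OC(=O)c1cccc(NC(=O)C2CCCN(C(=O)c3cc(C(F)(F)F)cc(C(F)(F)F)c3)C2)c1` is one of two measured compounds: in an ADME assay on PC-3 cells (Homo sapiens) for cytotoxicity, read by WST assay, tested at 100 uM (on this read-out higher numbers stand for more inhibition at the one concentration tested (going by the name of the read-out) and lower numbers for less inhibition), compound 2 gives 0%, level with compound 1 `O=C(Nc1cccc(-c2ccco2)c1)C1CCCN(C(=O)c2cc(C(F)(F)F)cc(C(F)(F)F)c2)C1`, which in this assay gives 0%. Going by the values given here, the one measured step, no change at the digits printed from compound 1 to compound 2 (within the scatter), lies within the scatter. Compound 3 `O=C(Nc1cccc([N+](=O)[O-])c1)C1CCCN(C(=O)c2cc(C(F)(F)F)cc(C(F)(F)F)c2)C1` differs from compound 2 by nitro in place of tert-butoxycarbonyl on an aromatic carbon. The step from compound 1 to compound 2 bears on this change, since it also exchanged the group on that aromatic carbon and moved nothing; the step of a number 2 percentage points higher from compound 2 to compound 3 (within the scatter) is therefore expected to stay within the scatter, with no direction. For compound 3 an inhibition of 2% is estimated, between 0% and 12%.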

Compound 3, a percentage reported as inhibition, at one concentration (the size of the read-out at that concentration, not a potency): 9%
The estimate for compound 3 lay 7 percentage points below the measured number; the measured number falls inside the stated range.
By their numbers in this assay, from the lowest: compounds 1, 2 and 3 (each within the scatter of the next).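

At this aromatic carbon, nitro joins tert-butoxycarbonyl and furan-2-yl with no separation in this assay: a number 9 percentage points higher from compound 2 to compound 3 (within the scatter), and a number 9 percentage points higher from compound 1 to compound 3 (within the scatter). The exchange to a group with far fewer heavy atoms therefore leaves compound 3 within the scatter of both earlier compounds, so its nonzero number marks no trend. Nothing available explains this flat read-out.

Still open, going by these compounds, is whether an amine or a carboxylic acid on this aromatic carbon would give a number beyond the scatter. Also open, on these data alone, is whether any change to the shared core would do so.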